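Pyridin-2-yl in place of 2-chlorophenyl

A few compounds are considered here, and "the series" means these few. Any claim that something is new, unique, unknown or untested is made for them only; others in the source may bear on it.

Compounds 1 to 3 share one core and differ in a single ring group. In a functional assay on HeLa cells (Homo sapiens) for cytotoxicity, read by ELISA, with a stated time of 4 days (a lower number here means a stronger inhibitor, a higher number a weaker inhibitor), compound 1 `Cc1cccc(-c2cc(-c3ccoc3)cc(-c3ccc(Cl)s3)n2)c1` gives 23600 nM and compound 2 `Cc1ccc(-c2cc(-c3ccoc3)cc(-c3ccc(Cl)s3)n2)cc1` gives 28700 nM while compound 3 `Clc1ccc(-c2cc(-c3ccoc3)cc(-c3ccccc3Cl)n2)s1` gives 19000 nM and so sits within the scatter of both others.

The change to compound 4 `Clc1ccc(-c2cc(-c3ccoc3)cc(-c3ccccn3)n2)s1` falls at that same place, on an aromatic carbon next to the ring nitrogen: pyridin-2-yl in place of 2-chlorophenyl on an aromatic carbon describes it, pyridin-2-yl in place of 2-chlorophenyl.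

Within the data shown here, three measured steps bear on this place. The step of a 1.2-fold lower number from compound 1 to compound 3 (0.09 log units; within the scatter) and the step of a 1.5-fold lower number from compound 2 to compound 3 (0.18 log units; within the scatter) bring in 2-chlorophenyl, and the step of a 1.2-fold higher number from compound 1 to compound 2 (0.08 log units; within the scatter) swaps 3-methylphenyl for 4-methylphenyl. All three stay within the scatter. None of them, however, tests a ring nitrogen in this group, so the guide is weak.

The expected step is a 1.2-fold higher number from compound 3 to compound 4 (0.06 log units; within the scatter) and thus nothing beyond the scatter. For compound 4 the estimate is 22000 nM with 9000 nM to 50000 nM as the expected range around it.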

Compound 4, half-maximal inhibitory concentration: 21600 nM
The estimate for compound 4 lay 1.0-fold (0.01 log units) above the measured number; the range from low to high includes it.
By their numbers in this assay, from the lowest: compounds 3, 4, 1 and 2 (each within the scatter of the next).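

Among these compounds, only compound 4 has a ring nitrogen in this group, and in this assay replacing 2-chlorophenyl with pyridin-2-yl gives a 1.1-fold higher number from compound 3 to compound 4 (0.06 log units; within the scatter). The comparisons with the methylphenyl compounds, a 1.3-fold lower number from compound 2 to compound 4 (0.12 log units; within the scatter) and a 1.1-fold lower number from compound 1 to compound 4 (0.04 log units; within the scatter), also stay within the scatter, so this assay does not separate pyridin-2-yl from the three phenyl groups at this position. No measurement shown here offers an explanation for this result.

From the compounds shown here alone, it remains open whether a different kind of group at this place, such as an amine or a carboxylic acid, would move the number beyond the scatter. Going by these compounds, it is also open whether this swap would read the same without the 5-chlorothiophen-2-yl and furan-3-yl groups on the shared core.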